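The source may hold more compounds than are shown below. What is called first, only, known or untested is meant among the compounds shown, and "the series" means these compounds.

Working notes on the chalcone series in a functional assay on the whole organism (strain Kunming) for inhibition, with Mus musculus as the target, with a stated time of 1 h, at a dose of 40 mg/kg by the oral route; on this read-out lower numbers stand for less inhibition and higher numbers for more inhibition at the one dose given (going by the name of the read-out). Compound 1 `O=C(/C=C/c1ccccc1)c1ccc(N2CCN(c3ccc(Cl)c(Cl)c3)CC2)cc1` gives 13.4%; compound 2 `Cc1ccc(N2CCN(c3ccc(C(=O)/C=C/c4ccccc4)cc3)CC2)c(C)c1` gives 15%; compound 3 `O=C(/C=C/c1ccccc1)c1ccc(N2CCN(c3ccccc3)CC2)cc1` gives 3.71%. Among the compounds with values here, compound 1 stands second highest of the three, with compound 2 nearest, a number 1.6 percentage points higher from compound 1 to compound 2 (within the scatter), and compound 3 furthest, a number 9.7 percentage points lower from compound 1 to compound 3 (within the scatter); only the step of a number 11.3 percentage points lower from compound 2 to compound 3 (beyond the scatter) exceeds the scatter. Compound 4 `O=C(/C=C/c1ccccc1)c1ccc(N2CCN(S(=O)(=O)c3ccc(Br)cc3)CC2)cc1` differs from compound 1 by (4-bromophenyl)sulfonyl in place of 3,4-dichlorophenyl on an amine nitrogen in a ring. Within the data shown here, the two measured steps at the same ring nitrogen, a number 1.6 percentage points higher from compound 1 to compound 2 (within the scatter) and a number 9.7 percentage points lower from compound 1 to compound 3 (within the scatter), both stayed within the scatter, and no measured step covers a sulfonyl on that nitrogen. The expected step is therefore a number 1.4 percentage points lower from compound 1 to compound 4 (within the scatter), none beyond the scatter. Compound 4 is estimated at 12%, within 0% to 28%.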

Compound 4, a percentage reported as inhibition, in the whole organism at one dose (the size of the read-out at that dose, not a potency): 47.4%
Estimate against measurement, compound 4: 35.4 percentage points below; measured number above the stated range.
By their numbers in this assay, from the lowest: compounds 3, 1 and 2 (each within the scatter of the next, the first and the last beyond it); then compound 4.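

Within the data shown here, at the ring nitrogen, (4-bromophenyl)sulfonyl produces the first large steps in this assay (a number 34 percentage points higher from compound 1 to compound 4 (beyond the scatter); a number 32.4 percentage points higher from compound 2 to compound 4 (beyond the scatter); a number 43.7 percentage points higher from compound 3 to compound 4 (beyond the scatter)). Compound 4 therefore lies beyond the scatter of all three compounds with a phenyl-based group on that nitrogen, so this position can carry a far larger change than those groups showed. No evidence on the cause of this gain is at hand.

From the compounds shown here alone, compound 4 brings in the sulfonyl and the bromine together, so the share of each stays open. Going by these compounds, how a plain phenylsulfonyl, a methylsulfonyl or an acetyl on that nitrogen would read also stays open.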